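A few compounds are considered here, and "the series" means these few. Any claim that something is new, unique, unknown or untested is made for them only; others in the source may bear on it.

Measured so far in an ADME assay on MT4 cells (Homo sapiens) for cytotoxicity, read by MTT assay, with a stated time of 96 h; on this read-out lower numbers stand for higher toxicity in this test and higher numbers for lower toxicity in this test:
- compound 1, `CC(=O)Nc1ccc(-c2nc3cc(C(F)(F)F)ccc3[nH]2)cc1`, gives 19000 nM
- compound 2, `CCC(=O)Nc1ccc(-c2nc3cc(C(F)(F)F)ccc3[nH]2)cc1`, gives >= 100000 nM; this is a limit of the assay, not a number
- compound 3, `CCC(=O)Nc1ccc(-c2nc3cc(C(F)(F)F)ccc3n2C)cc1`, gives 8000 nM

Compound 2 therefore stands at the top of the numbers shown, at the limit of >= 100000 nM in this assay, at which 1 of the 3 values shown sits, and no value is known for it beyond that. Among the compounds with values here, two measured steps touch compound 2. One is an at least 5.2-fold higher number from compound 1 to compound 2 (0.72 log units; beyond the scatter), on the chain of the propanoylamino group. The other is an at least 12-fold lower number from compound 2 to compound 3 (1.09 log units; beyond the scatter), on the shared core. Both are methyl-for-hydrogen changes, and neither alters the group that is exchanged now.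

Compound 4, `COc1ccc(-c2nc3cc(C(F)(F)F)ccc3[nH]2)cc1`, differs from compound 2 by methoxy in place of propanoylamino on an aromatic carbon. No measured step exchanges the whole group at that position, so the two steps shown give no direct guide to the size or direction of this change; they only show that the series moves across a wide span in this assay, with compound 1 at a number below the limit. Compound 4 is estimated at 40000 nM, expected to fall within 10000 nM to 100000 nM. This corresponds to an expected step of an at least 2.5-fold lower number from compound 2 to compound 4 (0.39 log units; beyond the scatter), with the chance that only a limit is again reported being substantial.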

Compound 4, half-maximal cytotoxic concentration: 2000 nM
Compound 4: the middle estimate sits 20-fold (1.30 log units) above what was measured, and the stated range ends above it.
By their numbers in this assay, from the lowest: compound 4; then compound 3; then compound 1. At a limit, above all of these: compound 2.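

In this assay, the aromatic carbon para to a large group responds strongly to exchange of the whole substituent, not only to methyl-for-hydrogen changes on the chain or the shared core: methoxy in place of propanoylamino gives an at least 50-fold lower number from compound 2 to compound 4 (1.69 log units; beyond the scatter). That step starts from a limit for compound 2 and not from a number: the limit of >= 100000 nM in this assay, at which 1 of the 4 values shown sits. Methoxy in place of acetamido gives a 9.5-fold lower number from compound 1 to compound 4 (0.98 log units; beyond the scatter), a step between two numbers, so the lower number with methoxy does not rest on the limit alone.

With these compounds, the effect of adding methoxy cannot be separated from the effect of removing the acylamino group, and a hydroxyl group, a free amine or plain hydrogen on the same carbon would help to separate them. From the compounds shown here alone, it also remains open whether methyl on the aromatic nitrogen, seen so far only as an at least 12-fold lower number from compound 2 to compound 3 (1.09 log units; beyond the scatter), would shift the number in the same direction with methoxy in place, and how a longer acyl chain would compare with propanoylamino.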